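The source may report more compounds than this note shows. Statements on the series, on what has been measured and on what is new or still open speak of the compounds shown alone.

Compound 1, `COc1cc2c(Oc3ccc(NC(=O)c4cc(-c5ccccc5)ccn4)cc3F)ccnc2cc1OCCCN1CCN(C)CC1`, gives 91 nM in a functional assay on NCI-H460 cells (Homo sapiens) for cytotoxicity, read by MTT assay, with a stated time of 72 h; a higher number here means a weaker inhibitor, a lower number a stronger inhibitor. Compound 2, `COc1ccc(-c2ccnc(C(=O)Nc3ccc(Oc4ccnc5cc(OCCCN6CCN(C)CC6)c(OC)cc45)c(F)c3)c2)cc1`, gives 370 nM in this assay, and the change between them is methoxy in place of hydrogen on an aromatic carbon, which made a 4.1-fold higher number from compound 1 to compound 2 (0.61 log units; beyond the scatter). Compound 3, `COc1ccc(-c2ccnc(C(=O)Nc3ccc(Oc4ccnc5cc(OCCCN6CCCC6)c(OC)cc45)c(F)c3)c2)cc1`, gives 200 nM; its change from compound 2 is a 1.9-fold lower number from compound 2 to compound 3 (0.27 log units; within the scatter).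

Compound 4, `COc1ccc(-c2ccnc(C(=O)Nc3ccc(Oc4ccnc5cc(OCCCN6CCCC6)c(OC)cc45)c(F)c3)c2)c(OC)c1`, has not yet been measured. It differs from compound 3 by methoxy in place of hydrogen on an aromatic carbon. The difference between the core of compound 1 and the core of compound 3 is not broken down here. The new methoxy in compound 4 sits ortho to a large group and meta to a methoxy group, while in compound 2 it sits para to a large group, so this is the same kind of change rather than the same one.

Because a 4.1-fold higher number from compound 1 to compound 2 (0.61 log units; beyond the scatter) weakened inhibition, a step of similar direction is expected here, a 2.3-fold higher number from compound 3 to compound 4 (0.35 log units; beyond the scatter), though the different place around the new group leaves the size uncertain. Compound 4 is therefore estimated at 450 nM, between 150 nM and 1400 nM.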

Compound 4, half-maximal inhibitory concentration: 520 nM
For compound 4 the middle estimate is 1.2-fold (0.06 log units) below the measured one, within the range that was stated.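

Going from 4-methoxyphenyl to 2,4-dimethoxyphenyl in this assay gives a 2.6-fold higher number from compound 3 to compound 4 (0.41 log units; beyond the scatter) and so weakens inhibition. A methoxy in place of hydrogen on this aromatic ring therefore weakens inhibition on both cores, and the two steps cannot be told apart in size: the same change on two cores in this assay, a 4.1-fold higher number (0.61 log units; beyond the scatter) from compound 1 to compound 2 and a 2.6-fold higher number (0.41 log units; beyond the scatter) from compound 3 to compound 4, 1.6-fold (0.19 log units) apart, within the scatter of two such steps. Going by these compounds alone, this rests on only two pairs, with the new methoxy at a different place on the ring in each, so it shows that the direction carried over between these two cores, but not that it would carry over to another core, that the place on the ring makes no difference, or why inhibition weakens.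

The compounds shown leave open what a 2-methoxyphenyl group alone would give, and whether a fluorine or a hydroxyl group in place of the new methoxy would move the number the same way. They also leave open whether the step would hold with a morpholine in place of the pyrrolidin-1-yl group.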